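Swapping chloro for iodo on compound 3

The source may report more compounds than this note shows. Statements on the series, on what has been measured and on what is new or still open speak of the compounds shown alone.

Compound 1 `N=C(N)c1ccc(COc2ccc(N)cc2)cc1`: > 271000000 nM (a limit)
Compound 2 `N=C(N)c1cccc(COc2cccc([N+](=O)[O-])c2)c1`: 104000000 nM
Compound 3 `N=C(N)c1ccc(COc2ccc(C(=N)N)cc2Cl)cc1`: 3200000 nM

In an ADME assay on L6 cells (Rattus norvegicus) for cytotoxicity, read by resazurin assay, with a stated time of 72 h (on this read-out higher numbers stand for weaker inhibition and lower numbers for stronger inhibition), compound 2 gives 104000000 nM and compound 3 gives 3200000 nM in the same test. Compound 3 holds the lower of the two true numbers, and the gap between the two lies beyond the scatter. Compound 1 reports only a limit, > 271000000 nM here.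

Compound 4 `N=C(N)c1ccc(COc2ccc(C(=N)N)cc2I)cc1` carries iodo in place of chloro on an aromatic carbon and is still unmeasured. Among the measured compounds shown here, no measured pair shows this change, so no step beyond the scatter is expected in this assay here. The expected shift is a 1.3-fold lower number from compound 3 to compound 4 (0.11 log units; within the scatter) as estimated. The expected value for compound 4 is 2500000 nM with a range from 800000 nM to 8000000 nM as estimated.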

Compound 4, half-maximal inhibitory concentration: 5300000 nM
Compound 4: the middle estimate sits 2.1-fold (0.33 log units) below what was measured; the measured number falls inside the stated range.
By their numbers in this assay, from the lowest: compounds 3 and 4 (each within the scatter of the next); then compound 2. At a limit, above all of these: compound 1.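

In this assay, among the compounds shown here, iodo in place of chloro on an aromatic carbon gives a 1.7-fold higher number from compound 3 to compound 4 (0.22 log units; within the scatter), the first change at a single place that can be read here. At this carbon, ortho to a large group, the two halogens cannot be told apart on this read-out. Nothing measured here speaks to why they read alike. On these data alone, what remains open is whether an amine, a methoxy group or a carboxylic acid on this carbon would stay level with compound 3 and compound 4 or move away from them. As far as these compounds go, whether a bare hydrogen there would read the same also stays open.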